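The source may hold more compounds than are shown below. What is called first, only, known or untested is meant among the compounds shown, and "the series" means these compounds.

Series notes. The shared core is varied only at the saturated chain carbon bound to a carbonyl carbon and an oxygen on a saturated carbon. Compound 1 `COC(C)(C)[C@@H](O)C(=O)N1N=CC[C@H]1C(=O)NCc1cc(Cl)ccc1-n1cnnn1` carries 1-methoxy-1-methylethyl there; in a functional assay on a cell-free system (plasma, Homo sapiens), with a stated time of 3 min (on this read-out higher numbers stand for weaker inhibition and lower numbers for stronger inhibition), compound 1 gives 3700 nM. Compound 2 `O=C(NCc1cc(Cl)ccc1-n1cnnn1)[C@@H]1CC=NN1C(=O)[C@H](O)c1ccccc1F` carries 2-fluorophenyl, and in this assay compound 2 gives 1100 nM. Compound 3 `O=C(NCc1cc(Cl)ccc1-n1cnnn1)[C@@H]1CC=NN1C(=O)[C@H](O)C1CCCCC1` carries cyclohexyl, and in this assay compound 3 gives 970 nM. Compound 3 has the lowest of the three numbers, but its separation from compound 2 is only a 1.1-fold lower number from compound 2 to compound 3 (0.05 log units; within the scatter), which is within the scatter, so the two cannot be ordered; against compound 1 the step is a 3.8-fold lower number from compound 1 to compound 3 (0.58 log units; beyond the scatter), and compound 2 shows a matching a 3.4-fold lower number from compound 1 to compound 2 (0.53 log units; beyond the scatter).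

Compound 4 `O=C(NCc1cc(Cl)ccc1-n1cnnn1)[C@@H]1CC=NN1C(=O)[C@H](O)c1ccccc1` differs from compound 3 as follows: phenyl in place of cyclohexyl on a saturated chain carbon bound to a carbonyl carbon and an oxygen on a saturated carbon. Within the data shown here, the step that bears on it most directly is a 1.1-fold lower number from compound 2 to compound 3 (0.05 log units; within the scatter), which places a six-membered aromatic ring and the cyclohexyl within the scatter of each other; no measured pair separates phenyl from 2-fluorophenyl, so the fluorine's contribution is unknown. The expectation for compound 4 is therefore no step beyond the scatter, a 1.2-fold higher number from compound 3 to compound 4 (0.09 log units; within the scatter). Compound 4 is estimated in this assay at 1200 nM, with a range from 500 nM to 2800 nM.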

Compound 4, half-maximal inhibitory concentration: 840 nM
Estimate against measurement, compound 4: 1.4-fold (0.15 log units) above, and the stated range covers the measured number.
By their numbers in this assay, from the lowest: compounds 4, 3 and 2 (each within the scatter of the next); then compound 1.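

At the saturated chain carbon bound to a carbonyl carbon and an oxygen on a saturated carbon, neither phenyl in place of cyclohexyl (a 1.2-fold lower number from compound 3 to compound 4 (0.06 log units; within the scatter)) nor hydrogen in place of fluoro on an aromatic carbon (a 1.3-fold lower number from compound 2 to compound 4 (0.12 log units; within the scatter)) gives a step that can be read in this assay, so this pair now shows directly that the fluoro makes no measurable difference here, and the aromatic and non-aromatic six-membered rings remain indistinguishable. Unsubstituted phenyl also keeps the modest separation from the 1-methoxy-1-methylethyl group (a 4.4-fold lower number from compound 1 to compound 4 (0.64 log units; beyond the scatter)), which makes compound 1 the only compound set apart, while compounds 2, 3 and 4 form one group that cannot be ordered. No measurement shown here offers an explanation for these results.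

From the compounds shown here alone, it remains open whether an amine, a carboxylic acid or a longer chain such as n-butyl at this carbon would move the number beyond the scatter of this group. Also open, going by these compounds, is whether chloro or methoxy in place of fluoro on the aromatic carbon would separate from hydrogen, given that fluoro does not.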